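The source may hold more compounds than are shown below. What is called first, only, known or untested is meant among the compounds shown, and "the series" means these compounds.

Measured so far:
compound 1, `Cn1c(=O)c2nc(-c3ccc(-c4ccccc4)cc3)[nH]c2n(C)c1=O` — 3.5 nM
compound 2, `CCn1c(=O)c2nc(-c3ccc(S(=O)(=O)NCCCN(C)C)cc3)[nH]c2n(CC)c1=O` — 1.6 nM
compound 3, `Cn1c(=O)c2nc(-c3ccc([N+](=O)[O-])cc3N)[nH]c2n(C)c1=O` — 2.5 nM

All three compounds share one core and were tested in an assay for binding affinity to adenosine receptor A1 (Bos taurus); on this read-out lower numbers stand for stronger inhibition and higher numbers for weaker inhibition. Compound 1, with a phenyl on its outer aromatic ring, gives 3.5 nM, the highest of the three numbers. Compound 3 lies closest to it: its number is lower, but by a margin that stays within the scatter of repeated measurements, so the two cannot be told apart. Compound 2 is the furthest away; its lower number sits just beyond the scatter, so compound 2 binds somewhat more tightly than compound 1.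

The step to be considered leads from compound 1 to compound 4, `CCCCOc1ccc(-c2nc3c(=O)n(C)c(=O)n(C)c3[nH]2)cc1`. The change is butoxy in place of phenyl on an aromatic carbon. Within the data shown here, no measured pair in this set shows this kind of exchange, so there is no directly comparable step to lean on. What the three measured compounds do show is that rather different groups at this position all land within a narrow band of numbers. On that basis the step of a 1.1-fold higher number from compound 1 to compound 4 (0.06 log units; within the scatter) is expected to be small, in either direction, and not clearly beyond the scatter. For compound 4 the expected value in this assay is 4 nM, with a plausible range from 1.5 nM to 12 nM.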

Compound 4, half-maximal inhibitory concentration: 4 nM
The estimate for compound 4 equals the measured number at the digits printed, within the range that was stated.
By their numbers in this assay, from the lowest: compounds 2, 3, 1 and 4 (each within the scatter of the next, the first and the last beyond it).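

Replacing phenyl with butoxy on an aromatic carbon, para to a large group, gives a 1.1-fold higher number from compound 1 to compound 4 (0.06 log units; within the scatter) in this assay, so this exchange makes no difference that the scatter allows anyone to read. Among these compounds, this is the first direct comparison at this position, and it shows that a number in this range does not depend on the phenyl here: a chain with no ring, carrying an oxygen and one hydrogen-bond acceptor, reads the same as a six-membered aromatic ring of carbon only. Nothing in the data explains why these two quite different groups read alike.

Going by these compounds, a single pair cannot show how far this tolerance extends, so it remains open whether a carboxylic acid, an amine, or a chain longer than butoxy, such as hexyloxy, would stay at similar numbers in the same place. On these data alone, it is also open whether the exchange of phenyl for butoxy would behave the same way on a core with ethyl groups in place of the methyl groups of compound 1.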